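This account rests on a few compounds, and the source may have more. Where it says the series, first, only, none or still open, it means among the compounds named here.

Compound 3 `CC1(c2ccccc2)CC(=O)N(CC(=O)N2CCN(c3ccccc3Cl)CC2)C1=O` gives 100 mg/kg in a functional assay on the whole organism (strain CD-1) with Mus musculus as the target, with a stated time of 2 h (a lower number here means that less compound is needed, a higher number that more compound is needed for the effect), the lowest of the two numbers reported. Compound 1 `CC1(c2ccccc2)CC(=O)N(CC(=O)N2CCN(c3ccc(Cl)cc3)CC2)C1=O` gives 300 mg/kg in this assay. Compound 2 `CC1(c2ccccc2)CC(=O)N(CC(=O)N2CCN(c3cccc(Cl)c3)CC2)C1=O` gives "not active" (no number reported) in this assay, with no number given. Among the measured compounds shown here, the single measured step is a 3.0-fold lower number from compound 1 to compound 3 (0.48 log units; beyond the scatter), a modest step beyond the scatter that concerns only where the chloro sits on the ring. Compound 4 `COc1ccccc1N1CCN(C(=O)CN2C(=O)CC(C)(c3ccccc3)C2=O)CC1` departs from compound 3 in a different way: methoxy in place of chloro on an aromatic carbon. For the measured compounds named here, no measured pair shows methoxy replacing chloro, so no step bears on this change directly, and the position of the group is kept. The expectation for compound 4 is therefore a step within the scatter, no change at the digits printed from compound 3 to compound 4 (within the scatter). Compound 4 is estimated at 100 mg/kg, with a range from 50 mg/kg to 300 mg/kg.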

Compound 4, minimum effective dose: "not active" (no number reported)
The entry for compound 4 holds no number; no gap can be computed for the estimate.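

Among the compounds shown here, compound 4 carries no number, so no step from compound 3 to compound 4 can be read. The compounds shown leave open how far 2-methoxyphenyl stands from 2-chlorophenyl in size of effect. No measurement at hand bears on this result.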